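Permeability of a reversed, methylated amide with a nitrile

The source may hold more compounds than are shown below. What is called first, only, known or untested is meant among the compounds shown, and "the series" means these compounds.

Compound 1, `CN(C)CCC(=O)Nc1ccc([C@H]2[C@@H](F)[C@@H](F)C[C@@H](F)[C@H]2F)cc1`, was measured in an ADME assay on MDCK-MDR1 cells (Canis lupus familiaris) for permeability, in the apical to basolateral direction, with a stated time of 180 min (on this read-out lower numbers stand for lower permeability and higher numbers for higher permeability), and gave 3.7 10^-6 cm/s. Among the three compounds with numbers, compound 1 stands second highest. Compound 3, `CN(Cc1cccnc1)C(=O)c1ccc(C2CCCCC2)cc1`, gave 12.1 10^-6 cm/s in this assay, and compound 2, `O=C(Cn1ccnc1)Nc1ccc([C@H]2[C@@H](F)[C@@H](F)C[C@@H](F)[C@H]2F)cc1`, gave 0.9 10^-6 cm/s. For the measured compounds named here, the only step between measured compounds that differ in one place is a 4.1-fold lower number from compound 1 to compound 2 (0.61 log units; beyond the scatter), the exchange of 1H-imidazol-1-yl for (dimethylamino)methyl on a saturated chain carbon bound to a carbonyl carbon.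

Compound 4, `CN(CCC#N)C(=O)c1ccc([C@H]2[C@@H](F)[C@@H](F)C[C@@H](F)[C@H]2F)cc1`, has not yet been measured in this assay. It differs from compound 1 by (2-cyanoethyl)(methyl)carbamoyl in place of ((2-(dimethylamino)ethyl)carbonyl)amino on an aromatic carbon. Going by the values given here, the measured step from compound 1 to compound 2 concerns a different exchange on the chain and offers no direct guide here; the reversal of the amide, the loss of the donor and the entry of the nitrile have no counterpart among the measured steps. The higher number of compound 3, the other tertiary amide, is the only pointer, and it is not a single-place change from compound 1. He therefore expects a modest rise, a 2.0-fold higher number from compound 1 to compound 4 (0.31 log units; beyond the scatter), that may or may not exceed the scatter. His estimate for compound 4 in this assay is 7.5 10^-6 cm/s, with a range from 3 10^-6 cm/s to 18 10^-6 cm/s.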

Compound 4, apparent permeability: 8.1 10^-6 cm/s
Compound 4: the middle estimate sits 1.1-fold (0.03 log units) below what was measured, and the stated range covers the measured number.
By their numbers in this assay, from the lowest: compound 2; then compound 1; then compounds 4 and 3 (each within the scatter of the next).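

For the compounds shown here, replacing the whole group on the aromatic carbon, para to a large group, gives in this assay a 2.2-fold higher number from compound 1 to compound 4 (0.34 log units; beyond the scatter), whereas the only earlier step from compound 1, an exchange further along the chain, went downward. The group that enters has the same count of heavy atoms as the one that leaves and, like it, no ring and no net charge, but it lacks the hydrogen-bond donor and adds a triple bond, so this position accepts a rebuilt substituent without a loss on this read-out. Nothing measured here accounts for the rise.

The compounds shown do not separate the reversal of the amide, the methyl on its nitrogen and the nitrile, since all three enter together in this one step. From the compounds shown here alone, a carbamoyl group keeping the amide hydrogen on the same 2-cyanoethyl chain, or the methylated amide ending in a dimethylamino group in place of the nitrile, would each isolate one of these changes, and how a longer chain would read also remains open.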